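A few compounds are considered here, and "the series" means these few. Any claim that something is new, unique, unknown or untested is made for them only; others in the source may bear on it.

Measured compounds in the series so far:

compound 1 `COc1ccc2c(c1)/C(=C/c1[nH]c3c(c1Cl)CN(C(C)=O)CC3)C(=O)N2`: 8 nM
compound 2 `CC(=O)N1CCc2[nH]c(/C=C3\C(=O)Nc4ccc(OC(C)C)cc43)cc2C1`: 4 nM
compound 3 `CC(=O)N1CCc2[nH]c(/C=C3\C(=O)Nc4ccc(C(F)(F)F)cc43)cc2C1`: 31 nM

In an assay on isolated protein for inhibition of Leucine-rich repeat serine/threonine-protein kinase 2 (Homo sapiens), read by fluorescence, with a stated time of 60 min (a higher number here means a weaker inhibitor, a lower number a stronger inhibitor), compound 3 stands highest of the three numbers, its steps to both compound 1 and compound 2 lying beyond the scatter; compound 1 is the nearer of the two, compound 2 the further. Going by the values given here, the only step measured at this position is a 7.8-fold higher number from compound 2 to compound 3 (0.89 log units; beyond the scatter), a modest rise on exchanging isopropoxy for trifluoromethyl.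

Compound 4 `CC(=O)N1CCc2[nH]c(/C=C3\C(=O)Nc4ccc(C#N)cc43)cc2C1` is the next substituent at the same place: cyano in place of trifluoromethyl on an aromatic carbon. Among the compounds with values here, no measured step involves cyano, so the bearing of the data is indirect. Within the data shown here, the one step at this position, the change from compound 2 to compound 3, shows that the group at this aromatic carbon moves the number only modestly, and the three measured values span a narrow band. The expectation for compound 4 is therefore a step of a 1.7-fold lower number from compound 3 to compound 4 (0.24 log units; within the scatter), most likely a small decrease back toward the values of compound 1 and compound 2, but with a range that also admits no change beyond the scatter.

Compound 4 is estimated at 18 nM in this assay, with a range of 6 nM to 60 nM.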

Compound 4, half-maximal inhibitory concentration: 7 nM
Compound 4: middle estimate off by 2.6-fold (0.41 log units), on the high side; the measured number falls inside the stated range.
By their numbers in this assay, from the lowest: compounds 2, 4 and 1 (each within the scatter of the next); then compound 3.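

In this assay, the exchange of trifluoromethyl for cyano gives a 4.4-fold lower number from compound 3 to compound 4 (0.65 log units; beyond the scatter), so the weaker result at this aromatic carbon belongs to trifluoromethyl and does not extend to every replacement of isopropoxy. Set against isopropoxy, cyano gives a 1.8-fold higher number from compound 2 to compound 4 (0.24 log units; within the scatter), which leaves these two groups indistinguishable here despite their different make-up, while trifluoromethyl alone stands apart, as the step of a 7.8-fold higher number from compound 2 to compound 3 (0.89 log units; beyond the scatter) also shows. Nothing at hand accounts for the difference between cyano and trifluoromethyl at this position.

Still open, as far as these compounds go, is whether an amine, a carboxylic acid or a longer alkoxy chain at this aromatic carbon would stay with isopropoxy and cyano or move towards trifluoromethyl, since three groups give too little to define what the position tolerates. Also open, from the compounds shown here alone, is whether the exchange of trifluoromethyl for cyano would give a step of similar size on the core of compound 1, which carries a chlorine that the other compounds lack.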